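This account rests on a few compounds, and the source may have more. Where it says the series, first, only, none or still open, it means among the compounds named here.

Compound 1 `O=C(c1ccccn1)N1CCC(NS(=O)(=O)c2cc(S(=O)(=O)c3ccccc3)ccc2C(F)(F)F)CC1` sits at the top of the three numbers measured in an assay on U2OS cells for inhibition of secreted frizzled-related protein 1 (Homo sapiens), read by a luciferase reporter, with a stated time of 18 h (a lower number here means that less compound is needed, a higher number that more compound is needed for the effect), where compound 1 gives 230 nM. Its two neighbours share the same core and differ only in the group on the amine nitrogen in the ring. Compound 2 `O=C(O)c1cccc(S(=O)(=O)N2CCC(NS(=O)(=O)c3cc(S(=O)(=O)c4ccccc4)ccc3C(F)(F)F)CC2)c1` carries a (3-carboxyphenyl)sulfonyl there and gives 190 nM in this assay, and compound 3 `N#Cc1cccc(S(=O)(=O)N2CCC(NS(=O)(=O)c3cc(S(=O)(=O)c4ccccc4)ccc3C(F)(F)F)CC2)c1` carries a (3-cyanophenyl)sulfonyl and gives 170 nM. The steps of a 1.2-fold lower number from compound 1 to compound 2 (0.08 log units; within the scatter) and a 1.4-fold lower number from compound 1 to compound 3 (0.13 log units; within the scatter) both stay within the scatter, as does a 1.1-fold lower number from compound 2 to compound 3 (0.05 log units; within the scatter), so nothing among these three can be ordered.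

Compound 4 `O=C(O)c1ccc(N2CCC(NS(=O)(=O)c3cc(S(=O)(=O)c4ccccc4)ccc3C(F)(F)F)CC2)cc1` is not yet measured. It differs from compound 1 as follows: 4-carboxyphenyl in place of (pyridin-2-yl)carbonyl on an amine nitrogen in a ring. For the measured compounds named here, the steps that bear on this change are the two exchanges of the (pyridin-2-yl)carbonyl for a substituted phenylsulfonyl, a 1.2-fold lower number from compound 1 to compound 2 (0.08 log units; within the scatter) and a 1.4-fold lower number from compound 1 to compound 3 (0.13 log units; within the scatter), each small. The replacement in compound 4 drops the sulfonyl and attaches the 4-carboxyphenyl itself, so the precedent is loose, yet the measured exchanges give no sign of a shift beyond the scatter. Compound 4 is therefore expected to show a 1.2-fold lower number from compound 1 to compound 4 (0.06 log units; within the scatter), nothing beyond the scatter. The estimate for compound 4 in this assay is 200 nM, with a range from 80 nM to 550 nM.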

Compound 4, half-maximal effective concentration: 230 nM
Compound 4: the middle estimate sits 1.2-fold (0.06 log units) below what was measured; the range from low to high includes it.
By their numbers in this assay, from the lowest: compounds 3, 2, 1 and 4 (each within the scatter of the next).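

In this assay, for the compounds shown here, the exchange at this position gives no change at the digits printed from compound 1 to compound 4 (within the scatter) even though the 4-carboxyphenyl stands directly on the amine nitrogen in the ring, so compound 4 shows what the earlier compounds could not: neither a carbonyl nor a sulfonyl link on this nitrogen is needed to keep the number within the scatter of the others. The same holds against the two sulfonyl compounds, with a 1.4-fold higher number from compound 3 to compound 4 (0.13 log units; within the scatter) and a 1.2-fold higher number from compound 2 to compound 4 (0.08 log units; within the scatter) both staying small, and the entering group counts 1 hydrogen-bond donor where the leaving (pyridin-2-yl)carbonyl counts 0 without any step moving beyond the scatter. Among these four compounds, therefore, three kinds of attachment of an aromatic ring to this nitrogen cannot be ordered, and no compound shown goes against this.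

The compounds shown leave open whether this flat picture depends on an aromatic ring at this position, since none carries an amine, a longer alkyl chain or a plain hydrogen on this nitrogen. Nothing is available here that explains why the numbers stay so close.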